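The compounds below may be only part of what the source reports. "The series", "measured", "known", "first", "only" and "open" are said of these compounds alone.

Working notes on the series. Among the compounds with values here, compound 1 `Cc1cccc2c1nc(COc1ccc(Cl)cc1)n2CCCC1CCNCC1` holds the lowest of the two numbers so far in an assay on AV12 cells for binding affinity to Neuropeptide Y receptor type 1 (Homo sapiens) (a lower number here means a stronger inhibitor, a higher number a weaker inhibitor), at 335 nM. Its nearest neighbour is compound 2 `CCOC(=O)CN1CCC(CCCn2c(COc3ccc(Cl)cc3)nc3c(C)cccc32)CC1`, which in this assay gives 427 nM; the step of a 1.3-fold higher number from compound 1 to compound 2 (0.11 log units; within the scatter) is within the scatter, so the two compounds cannot be separated on these numbers.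

Compound 3 `CCOC(=O)CCCN1CCC(CCCn2c(COc3ccc(Cl)cc3)nc3c(C)cccc32)CC1` is not yet measured. It differs from compound 1 as follows: 3-(ethoxycarbonyl)propyl in place of hydrogen on an amine nitrogen in a ring. Within the data shown here, the only measured step that bears on this change is a 1.3-fold higher number from compound 1 to compound 2 (0.11 log units; within the scatter), where (ethoxycarbonyl)methyl replaced hydrogen on an amine nitrogen in a ring and the number stayed within the scatter. Among the measured compounds shown here, the 3-(ethoxycarbonyl)propyl chain itself has no measured counterpart, so the expectation rests on that single step. No shift beyond the scatter is expected in this assay in either direction. For compound 3 the expected value in this assay is 400 nM, with a range of 180 nM to 900 nM. The step this estimate implies is a 1.2-fold higher number from compound 1 to compound 3 (0.08 log units; within the scatter).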

Compound 3, inhibition constant: 29 nM
For compound 3 the middle estimate is 14-fold (1.14 log units) above the measured one; the whole stated range lies above it.
By their numbers in this assay, from the lowest: compound 3; then compounds 1 and 2 (each within the scatter of the next).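

In this assay the group on the amine nitrogen of the six-membered ring does matter: 3-(ethoxycarbonyl)propyl in place of hydrogen gives a 12-fold lower number from compound 1 to compound 3 (1.06 log units; beyond the scatter) while the (ethoxycarbonyl)methyl group of compound 2 had left the number within the scatter. With the ester kept and the chain lengthened, 2-(ethoxycarbonyl)ethyl in place of ethoxycarbonyl on the saturated chain carbon gives a 15-fold lower number from compound 2 to compound 3 (1.17 log units; beyond the scatter) so among these compounds the large drop goes with the longer chain and not with the presence of the ester as such. No measurement available here accounts for the size of these steps.

The compounds shown leave open whether the ester is needed at all, or whether a carboxylic acid, an amide or a plain butyl chain on the same nitrogen would give a similar number. They also do not tell whether a still longer chain carrying the ester would lower the number further, or where a 2-(ethoxycarbonyl)ethyl group on that nitrogen would fall.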